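Adding an amino-bearing chain to compound 1

This account rests on a few compounds, and the source may have more. Where it says the series, first, only, none or still open, it means among the compounds named here.

For the measured compounds named here, in a functional assay on HCT-116 cells (Homo sapiens) for antiproliferative activity (on this read-out lower numbers stand for stronger inhibition and higher numbers for weaker inhibition), compound 1 `Cc1c2c(n3c1CCN(C)C[C@@H](C)[C@H](C)Nc1cc-3ccc1C(N)=O)CC(C)(C)CC2=O` gives 27 nM, the lowest of the three numbers measured so far. Compound 3 `COCCC(=O)N1CCCc2c(C)c3c(n2-c2ccc(C(N)=O)c(c2)N[C@@H](C)[C@@H]1C)CC(C)(C)CC3=O` gives 55 nM, and compound 2 `Cc1c2c(n3c1CCCN(C(=O)CN)[C@@H](C)[C@H](C)Nc1cc-3ccc1C(N)=O)CC(C)(C)CC2=O` gives 147 nM. Both carry a carbonyl-linked chain on a ring nitrogen, although neither shares the exact core of compound 1. Going by the values given here, the one measured step, a 2.7-fold lower number from compound 2 to compound 3 (0.43 log units; beyond the scatter), replaces amino with methoxymethyl on that chain.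

Compound 4 `Cc1c2c(n3c1CCN(C(=O)[C@@H](N)C(C)C)C[C@@H](C)[C@H](C)Nc1cc-3ccc1C(N)=O)CC(C)(C)CC2=O` has (1-amino-2-methylpropyl)carbonyl in place of methyl on an amine nitrogen in a ring. Its chain bears an amino group, as in compound 2 at 147 nM, so weaker inhibition is expected. The expected change is a 3.7-fold higher number from compound 1 to compound 4 (0.57 log units; beyond the scatter). For compound 4 the estimate is 100 nM, with an expected range from 35 nM to 300 nM.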

Compound 4, half-maximal inhibitory concentration: 30 nM
Estimate against measurement, compound 4: 3.3-fold (0.52 log units) above, and the stated range ends above it.
By their numbers in this assay, from the lowest: compounds 1, 4 and 3 (each within the scatter of the next, the first and the last beyond it); then compound 2.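

On the core of compound 1, the amine nitrogen in the ring accepts (1-amino-2-methylpropyl)carbonyl, with 7 heavy atoms in place of the single atom of methyl, and in this assay the result is a 1.1-fold higher number from compound 1 to compound 4 (0.05 log units; within the scatter). At this position, then, a far bigger chain bearing an amino group leaves the number within the scatter. Nothing shown gives a reason for this result.

On these data alone, it remains open whether the amino group matters here, since a hydroxyl in its place would test that on the same chain. A carboxylic acid or a longer chain on this nitrogen is also untested among these compounds.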